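The source may hold more compounds than are shown below. What is called first, only, known or untested is meant among the compounds shown, and "the series" means these compounds.

Working notes on the series. Of the compounds shown here, three have been measured in an assay on CHO cells for displacement of a labelled ligand from adenosine receptor A3 (Homo sapiens), read by scintillation counting, tested at 10 uM; a higher number here means more inhibition at the concentration tested (going by the name of the read-out), a lower number less inhibition. Compound 1 `CC(C)(C)Cc1c(/C=C/c2ccc(Cl)cc2)sc(N)c1C(=O)c1ccc(Cl)cc1` gives 11% in this assay. Compound 2 `CC(C)(C)Cc1c(Br)sc(N)c1C(=O)c1ccc(Cl)c(Cl)c1` gives 1% and compound 3 `CC(C)(C)Cc1c(-c2ccccc2)sc(N)c1C(=O)c1ccccc1Cl` gives 1%; both lie within the usual scatter of compound 1, so the three numbers cannot be separated, and all three sit at the low end of the inhibition scale. Within the data shown here, no pair of the measured compounds differs in only one place, so no single-change step is available. The unmeasured compound 4 `CC(C)(C)Cc1c(-c2ccsc2)sc(N)c1C(=O)c1ccc(Cl)cc1` differs from compound 1 as follows: thiophen-3-yl in place of 2-(4-chlorophenyl)ethenyl on an aromatic carbon. Given that compound 1 gives 11% and no measured change moves the read-out beyond the scatter, the step from compound 1 to compound 4 is expected to be a number 3 percentage points lower from compound 1 to compound 4 (within the scatter), no more than the scatter. Compound 4 is therefore estimated at 8% in this assay, with a range from 0% to 25%.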

Compound 4, a percentage reported as inhibition, at one concentration (the size of the read-out at that concentration, not a potency): 4%
The estimate for compound 4 lay 4 percentage points above the measured number; low and high end bracket the measured number.
By their numbers in this assay, from the lowest: compounds 2, 3, 4 and 1 (each within the scatter of the next).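

Thiophen-3-yl in place of 2-(4-chlorophenyl)ethenyl, on the aromatic carbon next to the ring sulfur, gives the first single-change step of the series: a number 7 percentage points lower from compound 1 to compound 4 (within the scatter) in this assay. The two groups therefore cannot be told apart at this position, even though the leaving group has a double bond outside aromatic rings and the entering one does not. No measurement bearing on this step is available to explain it.

From the compounds shown here alone, whether an amine or a carboxylic acid at this position would give a step beyond the scatter remains open. So does the effect of replacing the neopentyl group while this position stays fixed.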